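The source may report more compounds than this note shows. Statements on the series, on what has been measured and on what is new or still open speak of the compounds shown alone.

Notes on the series. Compound 3 `O=S(=O)(NCCCNCc1ccc(Cl)c(C(F)(F)F)c1)c1cc(C(F)(F)F)cc(C(F)(F)F)c1` stands second highest of the three numbers in a functional assay on BXPC-3 cells (Homo sapiens) for inhibition, read by MTT assay, with a stated time of 72 h; a higher number here means a weaker inhibitor of growth, a lower number a stronger inhibitor of growth; compound 3 gives 7800 nM. Its nearest neighbour is compound 2 `COc1ccc(CNCCCNS(=O)(=O)c2cc(C(F)(F)F)cc(C(F)(F)F)c2)cc1OC`, which gives 13000 nM, with a 1.7-fold lower number from compound 2 to compound 3 (0.22 log units; within the scatter). Going by the values given here, compound 1 `O=S(=O)(NCCCCNCc1ccc(Br)cc1)c1cc(C(F)(F)F)cc(C(F)(F)F)c1` gives 1700 nM, but it differs from compound 3 in more than one place, so no single step links them. Compound 4 `COc1ccccc1CNCCCNS(=O)(=O)c1cc(C(F)(F)F)cc(C(F)(F)F)c1` is not yet measured. The change is 2-methoxyphenyl in place of 4-chloro-3-(trifluoromethyl)phenyl on a saturated chain carbon bound to an amine nitrogen. Among the compounds with values here, the only step touching this saturated chain carbon bound to an amine nitrogen, a 1.7-fold lower number from compound 2 to compound 3 (0.22 log units; within the scatter), was within the scatter, and the 2-methoxyphenyl of compound 4 resembles the 3,4-dimethoxyphenyl of compound 2, so no step beyond the scatter is expected in this assay. For compound 4 the expected value is 10000 nM (range 4000 nM to 25000 nM). The estimated step is a 1.3-fold higher number from compound 3 to compound 4 (0.11 log units; within the scatter).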

Compound 4, concentration for 50% growth inhibition: 1700 nM
The estimate for compound 4 lay 5.9-fold (0.77 log units) above the measured number, and the stated range ends above it.
By their numbers in this assay, from the lowest: compounds 1 and 4 (each within the scatter of the next); then compounds 3 and 2 (each within the scatter of the next).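

In this assay, going by these compounds alone, this saturated chain carbon bound to an amine nitrogen now gives steps beyond the scatter, a 4.6-fold lower number from compound 3 to compound 4 (0.66 log units; beyond the scatter) and a 7.6-fold lower number from compound 2 to compound 4 (0.88 log units; beyond the scatter), where the only earlier step here stayed within it. The 2-methoxyphenyl therefore does not read like the 3,4-dimethoxyphenyl, although both carry methoxy. With no change at the digits printed from compound 1 to compound 4 (within the scatter), the change in chain and aryl group together shows no difference. Open, going by these compounds, is whether an unsubstituted phenyl or a 2-hydroxyphenyl here would match compound 4, and how a longer chain would read with the 2-methoxyphenyl. No measurement at hand accounts for this result.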